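The compounds below may be only part of what the source reports. "The series", "measured", "known", "first", "only" and "open" are said of these compounds alone.

Measured compounds:
Compound 1 `CC(C)NC(=O)c1ccc(C#Cc2ccccc2)nc1` — in an assay on HEK293 cells for displacement of a labelled ligand from metabotropic glutamate receptor 5 (Homo sapiens), with a stated time of 2 h (a higher number here means a weaker inhibitor, a lower number a stronger inhibitor), compound 1 gives 7100 nM.
Compound 2 `Cc1ccccc1C#Cc1ccc2c(n1)CCN(C)C2=O` — for compound 2 the result is only a limit of the assay, > 32000 nM.
Compound 3 `Cc1ccccc1C#Cc1ccc2c(n1)CCN(C(C)C)C2=O` — for compound 3 too the result is only a limit, > 32000 nM.

Compound 3 therefore stands at the limit itself, (the limit of > 32000 nM in this assay, at which 2 of the 3 values shown sit). Within the data shown here, the one step among the measured compounds that differs in a single place, a step that the two limits leave unreadable from compound 2 to compound 3, is unreadable, since both of its ends are limits. The step now followed leads to compound 4 `CC(C)N1CCc2nc(C#Cc3cccc(Cl)c3)ccc2C1=O` by the change (3-chlorophenyl in place of 2-methylphenyl on a triple-bonded carbon). Among the measured compounds shown here, no measured step bears on this change: nothing among the measured compounds compares a 3-chlorophenyl with a 2-methylphenyl on the triple-bonded carbon, and compound 1, which carries a plain phenyl there on a different core, gives a number well away from the limit. The expected step of an at least 1.6-fold lower number from compound 3 to compound 4 (0.20 log units; that floor lies within the scatter) is thus estimated from compound 3's limit alone. For the measured compounds named here, no step between the other compounds can be tied to it. Compound 4 is expected to give about 20000 nM, with a range from 5000 nM to 40000 nM.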

Compound 4, inhibition constant: 100 nM
Estimate against measurement, compound 4: 200-fold (2.30 log units) above; the whole stated range lies above it.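

In this assay, 3-chlorophenyl in place of 2-methylphenyl on the triple-bonded carbon gives an at least 320-fold lower number from compound 3 to compound 4 (2.50 log units; beyond the scatter), so the group at this place can lift the shared core clear of the assay limit. The result for compound 3 is only a limit, so this size is a floor: the limit of > 32000 nM in this assay, at which 2 of the 4 values shown sit. Among these compounds, the earlier step on the amide-type nitrogen cannot be read, which makes this the first change with a readable effect.

The compounds shown do not separate the gain from adding the chlorine, moving the substituent or losing the methyl, a question that a 3-methylphenyl or a 2-chlorophenyl on the same carbon would address. On these data alone, it also remains open whether 3-chlorophenyl has the same effect with methyl in place of isopropyl on the ring nitrogen.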